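The compounds below may be only part of what the source reports. "The series", "measured", "known", "first", "only" and "open" are said of these compounds alone.

Compound 1 `OC(CCn1nc2c(Br)c(Br)c(Br)c(Br)c2n1)c1ccc(Br)cc1` stands second highest of three numbers in a functional assay on MCF7 cells (Homo sapiens) for antiproliferative activity, read by MTT assay, with a stated time of 48 h, tested at 12.5 uM (on this read-out higher numbers stand for a weaker effect at the one concentration tested and lower numbers for a stronger effect), where compound 1 gives 107%. Compound 2 `OC(CCn1nc2c(Br)c(Br)c(Br)c(Br)c2n1)c1ccccc1` gives 113% and compound 3 `OC(CCn1nc2c(Br)c(Br)c(Br)c(Br)c2n1)c1cccc(Br)c1` gives 102%. The step of a number 6 percentage points higher from compound 1 to compound 2 (within the scatter) and the step of a number 5 percentage points lower from compound 1 to compound 3 (within the scatter) both stay within the scatter, while a number 11 percentage points lower from compound 2 to compound 3 (beyond the scatter) is modest. Compound 4 `COc1cccc(C(O)CCn2nc3c(Br)c(Br)c(Br)c(Br)c3n2)c1` differs from compound 1 by 3-methoxyphenyl in place of 4-bromophenyl on a saturated chain carbon bound to an oxygen on a saturated carbon and a saturated chain carbon. For the measured compounds named here, no measured compound carries a 3-methoxyphenyl group, so the only step that bears on this change is the move from 4-bromophenyl to 3-bromophenyl seen in a number 5 percentage points lower from compound 1 to compound 3 (within the scatter), which was small. One therefore expects no step beyond the scatter, namely a number 2 percentage points lower from compound 1 to compound 4 (within the scatter). Compound 4 is estimated at 105%, ranging from 90% to 120%.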

Compound 4, a percentage reported as activity, at one concentration (the size of the read-out at that concentration, not a potency): 97%
The estimate for compound 4 lay 8 percentage points above the measured number, within the range that was stated.
By their numbers in this assay, from the lowest: compounds 4, 3, 1 and 2 (each within the scatter of the next, the first and the last beyond it).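

In this assay the 3-methoxyphenyl group, which brings one hydrogen-bond acceptor, gives a number 10 percentage points lower from compound 1 to compound 4 (within the scatter) and, with methoxy in place of bromo, a number 5 percentage points lower from compound 3 to compound 4 (within the scatter), so neither change leaves the scatter. Only against the unsubstituted ring does a step pass it: a number 16 percentage points lower from compound 2 to compound 4 (beyond the scatter), in the same direction as a number 11 percentage points lower from compound 2 to compound 3 (beyond the scatter), although 4-bromophenyl goes against this pattern with a number 6 percentage points higher from compound 1 to compound 2 (within the scatter). As far as these compounds go, whether an amine or a carboxylic acid on this ring, or a longer chain at this carbon, would shift the number further remains open. Nothing available here explains these steps.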